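A new group on the sulfonyl sulfur of compound 1

The compounds below may be only part of what the source reports. "The series", "measured", "known", "first", "only" and "open" are said of these compounds alone.

Three related compounds have so far been tested for how well they dissolve. For the measured compounds named here, in a physicochemical assay for solubility, read by HPLC, using the shake flask method, measured as kinetic solubility, with a stated time of 20 h, at pH 6.5, tested at 200 uM (a lower number here means a less soluble compound, a higher number a more soluble compound), compound 1 `O=S(=O)(NCC1COC1)c1cccc(-c2ccc3nccc(-c4ccncc4)c3n2)c1` gives 20000 nM, the only actual number among them. Compound 2 `NS(=O)(=O)c1ccccc1-c1ccc2nccc(-c3ccncc3)c2n1` is reported only as a limit, < 5000 nM. Compound 3 `Cc1ccc(-c2ccnc3ccc(-c4cccc(S(N)(=O)=O)c4)nc23)cn1` is also reported only as a limit, < 5000 nM.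

Compound 4 `C[C@@H]1CN(S(=O)(=O)c2cccc(-c3ccc4nccc(-c5ccncc5)c4n3)c2)C[C@H](C)N1` has not yet been measured. It keeps the core of compound 1 and changes one group, with 3,5-dimethylpiperazin-1-yl in place of ((oxetan-3-yl)methyl)amino on a sulfonyl sulfur. The new group brings 2 defined stereocentres, and like the old one it carries no net charge.

Going by the values given here, no two measured compounds differ in just one place, so no measured step shows what a swap of this kind does in this assay. The expectation therefore starts from compound 1 at 20000 nM and leans modestly upward, towards a more soluble compound, with wide uncertainty. The expected size of the change is a 1.8-fold higher number from compound 1 to compound 4 (0.24 log units; within the scatter). For compound 4 the estimate is 35000 nM, with an expected range from 7000 nM to 170000 nM.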

Compound 4, solubility: 180000 nM
Beside the measured number, compound 4's estimate is 5.1-fold (0.71 log units) below it, outside the stated range (above it).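

With 3,5-dimethylpiperazin-1-yl in place of ((oxetan-3-yl)methyl)amino on a sulfonyl sulfur, this assay gives a 9.0-fold higher number from compound 1 to compound 4 (0.95 log units; beyond the scatter) and so a more soluble compound. This is the only step shown between two actual numbers. The core of compound 1 stays the same throughout it, and the change in the number goes with this one swap of group, showing that what sits on the sulfonyl sulfur can matter a great deal in this measurement. For the compounds shown here, compound 2 and compound 3 are each reported only as a limit, not as a number, and neither differs from compound 4 in just one place, so they add no further step and no step involving them can be read: the limit of < 5000 nM in this assay, at which 2 of the 4 values shown sit.

A single step cannot show which part of the swap goes with the higher number: the six-membered ring, its two methyl groups or their defined stereocentres. A plain piperazine without the methyl groups, or a morpholine, on the same sulfonyl sulfur would help separate these parts, and the data give no cause for the step.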